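Swapping methoxy for chloro on the pendant phenyl ring

The source may report more compounds than this note shows. Statements on the series, on what has been measured and on what is new or still open speak of the compounds shown alone.

Measured compounds:
- compound 1 `COc1ccc(C2=NN(C3=NC(=O)/C(=C4\C(=O)Nc5ccccc54)S3)C(c3ccc(OC)cc3)C2)cc1`: 100000 nM
- compound 2 `COc1ccc(C2CC(c3ccc4ccccc4c3)=NN2C2=NC(=O)/C(=C3\C(=O)Nc4ccccc43)S2)cc1`: 4800 nM
- compound 3 `COc1ccc(C2CC(c3ccc4ccccc4c3)=NN2C2=NC(=O)/C(=C3\C(=O)Nc4ccc(Br)cc43)S2)cc1`: 69 nM

In a functional assay on cells (Melanoma cell, Homo sapiens) for cytotoxicity, read by sulforhodamine B assay, with a stated time of 48 h (a lower number here means a stronger inhibitor of growth, a higher number a weaker inhibitor of growth), compound 2 stands second highest of the three numbers; compound 1 gives a higher number, compound 3 a lower one. Compound 4 `O=C1N=C(N2N=C(c3ccc4ccccc4c3)CC2c2ccc(Cl)cc2)S/C1=C1/C(=O)Nc2ccccc21` is not yet measured. It differs from compound 2 in one place: chloro in place of methoxy on an aromatic carbon. Among the measured compounds shown here, no measured step touches this exact position. The two known steps, a 21-fold lower number from compound 1 to compound 2 (1.32 log units; beyond the scatter) and a 70-fold lower number from compound 2 to compound 3 (1.84 log units; beyond the scatter), were both large, but each changed a different part of the shared core, so they give no direct guide to the expected size or direction of a 1.9-fold lower number from compound 2 to compound 4 (0.28 log units; within the scatter). A small step, within the usual scatter, is therefore expected, and compound 4 is estimated at 2500 nM, in the range 600 nM to 10000 nM.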

Compound 4, concentration for 50% growth inhibition: 350 nM
For compound 4 the middle estimate is 7.1-fold (0.85 log units) above the measured one; the whole stated range lies above it.
By their numbers in this assay, from the lowest: compound 3; then compound 4; then compound 2; then compound 1.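

In this assay, among the compounds shown here, exchanging 4-methoxyphenyl for 4-chlorophenyl gives a 14-fold lower number from compound 2 to compound 4 (1.14 log units; beyond the scatter), so this site on the pendant ring, which no earlier step had touched, strongly affects the read-out. The exchange replaces methoxy, with its hydrogen-bond acceptor, by a single chlorine atom. No measurement here explains the size of this step. The compounds shown cannot separate a gain from chloro from a loss of methoxy, since none carries plain hydrogen or an amine at this site. From the compounds shown here alone, whether chloro would also lower the number when combined with the bromo of compound 3 remains open.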